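A few compounds are considered here, and "the series" means these few. Any claim that something is new, unique, unknown or untested is made for them only; others in the source may bear on it.

In an ADME assay on the whole organism (Mus musculus, strain CD1) for pharmacokinetics, at a dose of 10 mg/kg by the oral route (a lower number here means less compound in the circulation, a higher number more compound in the circulation at the dose given), compound 1 (`CN1CCC(Oc2ccc(N3C(=S)N(c4cnc(C#N)c(C(F)(F)F)c4)C(=O)C34CCC4)cc2)CC1`) gives 980 nM, compound 2 (`Cc1cc(N2C(=O)C3(CCC3)N(c3ccc(OC4CCNCC4)nc3)C2=S)cnc1C#N`) gives 1880 nM and compound 3 (`N#Cc1ncc(N2C(=O)C3(CCC3)N(c3ccc(CN4CCNCC4)cc3)C2=S)cc1C(F)(F)F`) gives 840 nM. Going by the values given here, compound 1 lies within the scatter of both others, so the series so far shows no clear spread.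

Compound 4 (`COc1cc(N2C(=O)C3(CCC3)N(c3ccc(OC4CCN(C)CC4)cc3)C2=S)cnc1C#N`) differs from compound 1 in one place: methoxy in place of trifluoromethyl on an aromatic carbon, ortho to a cyano group (methoxy in place of trifluoromethyl on an aromatic carbon).

Among the compounds with values here, the only measured single-place step, a 1.2-fold lower number from compound 1 to compound 3 (0.07 log units; within the scatter), stays within the scatter and concerns a different group, so it bears on the new change only indirectly. Compound 2 also lacks trifluoromethyl, but it differs from compound 1 in more than one place and isolates nothing. Within the data shown here, no measured pair shows this exchange alone.

No step beyond the scatter is therefore expected in this assay, and no direction can be favoured. The expected step is a 1.0-fold higher number from compound 1 to compound 4 (0.01 log units; within the scatter). For compound 4 the estimated value is 1000 nM, with an expected range from 400 nM to 2500 nM.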

Compound 4, maximal plasma concentration: 2800 nM
Compound 4: middle estimate off by 2.8-fold (0.45 log units), on the low side, outside the stated range (above it).
By their numbers in this assay, from the lowest: compounds 3, 1, 2 and 4 (each within the scatter of the next, the first and the last beyond it).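

In this assay, methoxy in place of trifluoromethyl, ortho to a cyano group, gives a 2.9-fold higher number from compound 1 to compound 4 (0.46 log units; beyond the scatter) and is the only single-place step shown that lies beyond the scatter. The other such step, a 1.2-fold lower number from compound 1 to compound 3 (0.07 log units; within the scatter), stays within the scatter, so the read-out responds to this exchange on the pyridine-bearing end of compound 1 in a way that step did not show, though the finding rests on one pair. Nothing shown gives a measured reason for this step.

From the compounds shown here alone, whether the gain comes from methoxy itself or from the loss of trifluoromethyl stays open, and an amine or an ethoxy group at this position would help separate the two. Going by these compounds, it is also open whether the same exchange would carry over to compound 3, with its (piperazin-1-yl)methyl group.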